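A few compounds are considered here, and "the series" means these few. Any claim that something is new, unique, unknown or untested is made for them only; others in the source may bear on it.

Working notes on the series. Among the measured compounds shown here, in a functional assay on MCF7 cells (Homo sapiens) for antiproliferative activity, read by MTT assay, with a stated time of 72 h (a lower number here means a stronger inhibitor, a higher number a weaker inhibitor), compound 1 (`O=C(N/N=C/c1ccccc1)Nc1ccc(Oc2ccnc3[nH]ccc23)c(F)c1`) gives 2380 nM, the higher of the two numbers so far, while compound 2 (`O=C(N/N=C/c1cccc(Br)c1)Nc1ccc(Oc2ccnc3[nH]ccc23)c(F)c1`) gives 49 nM.

Compound 3 (`N#Cc1ccc(/C=N/NC(=O)Nc2ccc(Oc3ccnc4[nH]ccc34)c(F)c2)cc1`) differs from compound 1 by cyano in place of hydrogen on an aromatic carbon, para to a large group, or phenyl to 4-cyanophenyl.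

For the measured compounds named here, only one measured step bears on this change, bromo in place of hydrogen on an aromatic carbon: a 49-fold lower number from compound 1 to compound 2 (1.69 log units; beyond the scatter), a large step beyond the scatter. Going by the values given here, it is a single case with a different group, and no cyano compound has been measured yet. A step in the same direction is therefore expected in this assay, towards a lower number, but smaller and beyond the scatter. The expected step is a 6.0-fold lower number from compound 1 to compound 3 (0.77 log units; beyond the scatter). For compound 3 the estimated value is 400 nM, with an expected range of 60 nM to 2500 nM.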

Compound 3, half-maximal inhibitory concentration: "not active" (no number reported)
Nothing numeric was reported for compound 3; no gap can be computed for the estimate.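

Among the compounds shown here, compound 3 is reported in this assay as "not active", without a number, so no step from compound 1 to compound 3 can be read. No measurement shown bears on the reason for this result.

The compounds shown leave open how the phenyl to 4-cyanophenyl change compares in size with the change from compound 1 to compound 2.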